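This account rests on a few compounds, and the source may have more. Where it says the series, first, only, none or still open, it means among the compounds named here.

Going by the values given here, compound 2 `Oc1ccc(-c2cc(-c3ccccc3)nc(-c3ccccc3Cl)c2)cc1` is the only compound of this set with a number: in a functional assay on T47D cells (Homo sapiens) for cytotoxicity, read by CCK-8 assay and cell counting, with a stated time of 2 days (a lower number here means a stronger inhibitor, a higher number a weaker inhibitor), compound 2 gives 5460 nM. Compound 1 `Oc1cccc(-c2cc(-c3cccnc3)nc(-c3cccc(Cl)c3)c2)c1` carries no result in this assay, where compound 1 stands as "not determined" (no result reported). Compound 3 `Oc1ccc(-c2cc(-c3ccsc3)nc(-c3ccccc3Cl)c2)cc1` differs from compound 2 by thiophen-3-yl in place of phenyl on an aromatic carbon — thiophen-3-yl in place of phenyl on an aromatic carbon. Among the compounds with values here, no step between measured compounds exists to guide this change. Compound 3 is expected to shift little, the step of a 1.1-fold lower number from compound 2 to compound 3 (0.04 log units; within the scatter) being expected to stay within the usual scatter in either direction. Compound 3 is estimated at 5000 nM, within a range of 2000 nM to 15000 nM.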

Compound 3, half-maximal inhibitory concentration: 6110 nM
For compound 3 the middle estimate is 1.2-fold (0.09 log units) below the measured one; the measured number falls inside the stated range.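

In this assay, thiophen-3-yl in place of phenyl on the aromatic carbon next to the ring nitrogen gives a 1.1-fold higher number from compound 2 to compound 3 (0.05 log units; within the scatter). This first readable step shows that, with the 2-chlorophenyl and 4-hydroxyphenyl groups held fixed, this position takes a five-membered aromatic ring with sulfur as readily as the six-membered carbon ring. No measurement is at hand that would explain this result. The compounds shown leave open whether an amine, a carboxylic acid or a longer chain on this carbon would leave the number similarly unmoved.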